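The compounds below may be only part of what the source reports. "The series", "measured", "known", "first", "only" and "open" are said of these compounds alone.

Three compounds of the shared core have numbers in an ADME assay on the whole organism with Oryza sativa as the target, tested at 1 uM (on this read-out lower numbers stand for a stronger effect and higher numbers for a weaker effect at the one concentration tested), so far. Compound 1 `C[C@H](NC(=O)Nc1cccc(F)c1)c1ccccc1` gives 94%. Compound 2 `C[C@H](NC(=O)Nc1cccc(Cl)c1)c1ccccc1` gives 99%, the highest number of the three, with compound 3 nearest and compound 1 furthest, both within the scatter. Compound 3 `C[C@H](NC(=O)Nc1ccc(Cl)c(Cl)c1)c1ccccc1` gives 97%. Neither measured step moves beyond the scatter: a number 5 percentage points higher from compound 1 to compound 2 (within the scatter), and a number 2 percentage points lower from compound 2 to compound 3 (within the scatter).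

Compound 4 `C[C@H](NC(=O)Nc1cc(Cl)cc(Cl)c1)c1ccccc1` is next, not yet measured in this assay. It differs from compound 2 in one place: chloro in place of hydrogen on an aromatic carbon. The step that bears on it most directly is a number 2 percentage points lower from compound 2 to compound 3 (within the scatter), where the same kind of change was made and the number stayed within the scatter. On that basis no step beyond the scatter is expected for compound 4, and the step expected is a number 2 percentage points lower from compound 2 to compound 4 (within the scatter). Compound 4 is therefore estimated at 97%, with a range from 90% to 100%.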

Compound 4, a percentage reported as activity, at one concentration (the size of the read-out at that concentration, not a potency): 100%
For compound 4 the middle estimate is 3 percentage points below the measured one, and the stated range covers the measured number.
By their numbers in this assay, from the lowest: compounds 1, 3, 2 and 4 (each within the scatter of the next).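

In this assay, chloro in place of hydrogen at this carbon, meta to a chloro group and meta to a large group, gives a number 1 percentage points higher from compound 2 to compound 4 (within the scatter). The same kind of change at a different carbon of the ring gave a number 2 percentage points lower from compound 2 to compound 3 (within the scatter), so across compound 3 and compound 4 neither placement of the added chloro produces a step beyond the scatter. Nothing measured alongside these numbers accounts for this result.

The compounds shown carry only hydrogen, fluoro and chloro on this ring, so it remains open whether an amine, a carboxylic acid or a methoxy group at this carbon would give a step beyond the scatter. Also open, on these data alone, is what a longer chain in place of the methyl group on the shared core would do to the number.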